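Chain Length and Growth Inhibition in Prostate Cancer Cells

A few compounds are considered here, and "the series" means these few. Any claim that something is new, unique, unknown or untested is made for them only; others in the source may bear on it.

Compound 1 `C#CCN(C)Cc1cccc(NC(=O)CCCCC(=O)NO)c1` and compound 2 `C#CCN(C)Cc1cccc(NC(=O)CCCCCC(=O)NO)c1` share one core. In a functional assay on PC-3 cells (Homo sapiens) for inhibition, read by MTT assay, with a stated time of 48 h (a lower number here means a stronger inhibitor of growth, a higher number a weaker inhibitor of growth), compound 1 gives 5150 nM, and compound 2 gives 4630 nM. The change between them is (hydroxycarbamoyl)methyl in place of hydroxycarbamoyl on a saturated chain carbon, four bonds along the chain from a carbonyl carbon, and this step was a 1.1-fold lower number from compound 1 to compound 2 (0.05 log units; within the scatter). Compound 3 `C#CCN(C)Cc1ccc(NC(=O)CCCC(=O)NO)cc1` is built on a second core; the difference between the two cores is not broken down here. In this assay compound 3 gives only a limit, > 10000 nM, which is the limit of > 10000 nM in this assay, at which 1 of the 3 values shown sits. Compound 4 `C#CCN(C)Cc1ccc(NC(=O)CCCCC(=O)NO)cc1` has not been measured. It differs from compound 3 by (hydroxycarbamoyl)methyl in place of hydroxycarbamoyl on a saturated chain carbon, three bonds along the chain from a carbonyl carbon, the same kind of change as before, though here on a saturated chain carbon three bonds rather than four bonds along the chain from a carbonyl carbon. A similar small step is expected, an at least 1.2-fold lower number from compound 3 to compound 4 (0.09 log units; that floor lies within the scatter), because the earlier one was a 1.1-fold lower number from compound 1 to compound 2 (0.05 log units; within the scatter). Compound 4 is therefore estimated at 8000 nM, expected between 3000 nM and 20000 nM.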

Compound 4, concentration for 50% growth inhibition: > 10000 nM
Compound 4 gave a limit, no number; the forecaster's own chance of this, stated with the estimate: 45%; at least 1.2-fold (0.09 log units) between middle value and limit.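

Among these compounds, compound 3 and compound 4 each give only a limit, not a number, so no step between them can be read: the limit of > 10000 nM in this assay, at which 2 of the 4 values shown sit.

Going by these compounds, whether the longer chain changes growth inhibition on the core of compound 3 stays open.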